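Expectation for Compound 4 Against HT-29 Cells

The source may report more compounds than this note shows. Statements on the series, on what has been measured and on what is new or still open speak of the compounds shown alone.

Three compounds with a shared core were examined in a functional assay on HT-29 cells (Homo sapiens) for cytotoxicity, read by MTT assay, with a stated time of 72 h; a higher number here means a weaker inhibitor, a lower number a stronger inhibitor. Compound 1 `Fc1cc(Nc2cc(Nc3cccc(Cl)c3)ncn2)ccc1Oc1ccncc1-c1cccnc1` gives 690 nM. Compound 2 `Cn1c(=O)c(C(=O)Nc2ccc(Oc3ccncc3-c3cccnc3)c(F)c2)nn(-c2ccccc2F)c1=O`, which carries an amide on the core, gives 2100 nM. Compound 3 `COc1ccc(-n2nc(C(=O)Nc3ccc(Oc4ccncc4-c4cccnc4)c(F)c3)c3ccccc3c2=O)cc1`, also an amide, gives only "not determined" (no result reported) in this assay, so it cannot be placed on these numbers and is known here only by its structure. Compound 4 `O=C(Nc1ccc(Oc2ccncc2-c2cccnc2)c(F)c1)c1nn(-c2cccc(F)c2)c(=O)c2ccccc12` differs from compound 3 by one change: 3-fluorophenyl in place of 4-methoxyphenyl on an aromatic nitrogen. For the measured compounds named here, no step between two measured compounds resembles this change, so there is no measured guide to its size or direction; the expectation is that any shift from compound 3 to compound 4 stays within the usual scatter. The only anchors are the amide of compound 2 at 2100 nM and compound 1 at 690 nM. Compound 4 is therefore estimated at about 1800 nM in this assay, expected to fall between 400 nM and 8000 nM.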

Compound 4, half-maximal inhibitory concentration: 410 nM
Compound 4: the middle estimate sits 4.4-fold (0.64 log units) above what was measured, within the range that was stated.
By their numbers in this assay, from the lowest: compounds 4 and 1 (each within the scatter of the next); then compound 2.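

Compound 3 has no single number to set against compound 4, so no step can be read between them. The compounds shown leave open what exchanging 4-methoxyphenyl for 3-fluorophenyl does in this series. No evidence at hand bears on this result.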